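The compounds below may be only part of what the source reports. "The series", "measured", "known", "first", "only" and "open" are said of these compounds alone.

In a functional assay on G-361 cells (Homo sapiens) for antiproliferative activity, with a stated time of 72 h (a higher number here means a weaker inhibitor, a lower number a stronger inhibitor), compound 1 `OC[C@H]1O[C@@H](n2cnc3c(NCc4ccc(F)cc4)ncnc32)[C@H](O)[C@@H]1O` gives > 166000 nM, which is a limit of the assay and not a number. Compound 2 `OC[C@H]1O[C@@H](n2cnc3c(NCc4ccc(F)cc4Cl)ncnc32)[C@H](O)[C@@H]1O` gives > 166000 nM, which is also a limit. Compound 2 thus stands at the limit of > 166000 nM in this assay, at which 2 of the 2 values shown sit, with no number to place it by. Within the data shown here, the only measured step is a step that the two limits leave unreadable from compound 1 to compound 2, a chloro in place of hydrogen on an aromatic carbon, and it offers no size to scale from.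

Compound 3 `OC[C@H]1O[C@@H](n2cnc3c(NCc4cccc(O)c4O)ncnc32)[C@H](O)[C@@H]1O` has 2,3-dihydroxyphenyl in place of 2-chloro-4-fluorophenyl on a saturated chain carbon bound to a nitrogen on an aromatic ring. Among the measured compounds shown here, this change replaces both substituents of the ring, and no measured step covers it. Any number reported in this assay for compound 3 would have to lie on the stronger side of the limit of compound 2, while another limit remains quite possible. The estimated step is an at least 4.1-fold lower number from compound 2 to compound 3 (0.61 log units; beyond the scatter), towards stronger inhibition, with low confidence. For compound 3 the expected value is 40000 nM, with an estimated range of 5000 nM to 166000 nM.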

Compound 3, half-maximal inhibitory concentration: 16900 nM
For compound 3 the middle estimate is 2.4-fold (0.37 log units) above the measured one; the range from low to high includes it.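

In this assay, compound 3 is the only compound shown with a number and not a limit, so a change on a saturated chain carbon bound to a nitrogen on an aromatic ring can bring a readable antiproliferative value on the shared core. Going from 2-chloro-4-fluorophenyl to 2,3-dihydroxyphenyl gives an at least 9.8-fold lower number from compound 2 to compound 3 (0.99 log units; beyond the scatter), and going from 4-fluorophenyl to 2,3-dihydroxyphenyl gives an at least 9.8-fold lower number from compound 1 to compound 3 (0.99 log units; beyond the scatter); both steps start from a limit, so their true size stays open on the far side. The step between the two halogen-bearing compounds cannot be read, as compound 1 and compound 2 both sit at a limit of the assay and not at a number: the limit of > 166000 nM in this assay, at which 2 of the 3 values shown sit.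

Both hydroxy groups enter together and the halogens leave in the same change, so the compounds shown do not tell whether a single hydroxy group would be enough or whether the removal of fluorine and chlorine plays any part. Also open, as far as these compounds go, is how the series reads with methoxy or amino groups in place of the hydroxy groups of compound 3.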